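The source may report more compounds than this note shows. Statements on the series, on what has been measured and on what is new or still open speak of the compounds shown alone.

In a physicochemical assay for solubility, with a stated time of 24 h, at pH 4.5 (a lower number here means a less soluble compound, a higher number a more soluble compound), compound 1 (`O=C(NC[C@@H]1[C@H]2CN(C(=O)NCc3cc(Cl)cc(Cl)c3)C[C@@H]12)c1ccc2[nH]c(=O)oc2c1`) gives only a limit, < 1 ug/mL. Compound 2 (`N#Cc1cc(COC(=O)N2C[C@@H]3[C@@H](CNC(=O)c4ccc5[nH]c(=O)oc5c4)[C@@H]3C2)cc(OC(F)(F)F)c1`) also gives only a limit, < 1 ug/mL. Compound 3 (`N#Cc1cc(COC(=O)N2C[C@@H]3[C@@H](CNC(=O)c4ccc5[nH]nnc5c4)[C@@H]3C2)cc(C(=O)OC(F)(F)F)c1`) gives only a limit as well, < 1 ug/mL. The series therefore stands as follows: the limit of < 1 ug/mL in this assay, at which 3 of the 3 values shown sit. Compound 4 (`N#Cc1cc(COC(=O)N2C[C@@H]3[C@@H](CNC(=O)N4CCc5[nH]nnc5C4)[C@@H]3C2)cc(C(=O)OC(F)(F)F)c1`) is reached from compound 3 through (a group of 9 heavy atoms (5 carbon, 4 nitrogen; one five-membered aromatic ring with 3 hetero atoms, one six-membered non-aromatic ring with 1 hetero atom) in place of a group of 9 heavy atoms (6 carbon, 3 nitrogen; one five-membered aromatic ring with 3 hetero atoms, one six-membered aromatic ring of carbon only), on a carbonyl carbon); a six-membered aromatic ring of carbon only gives way to a six-membered non-aromatic ring with 1 hetero atom, on a carbonyl carbon. Going by the values given here, no measured pair shows a single change, so the expectation in this assay is tentative: a modest upward step, possibly no larger than the scatter. The estimated change is an at least 5.0-fold higher number from compound 3 to compound 4 (0.69 log units; beyond the scatter). For compound 4 the expected value is 5 ug/mL, within an estimated range of 1 ug/mL to 30 ug/mL.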

Compound 4, solubility: 26 ug/mL
Beside the measured number, compound 4's estimate is 5.2-fold (0.72 log units) below it, within the range that was stated.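

Compound 4 is the first compound in the series to give a value clear of the limit in this assay: the limit of < 1 ug/mL in this assay, at which 3 of the 4 values shown sit.
Compound 3 gives < 1 ug/mL, which is a limit and not a number. On a carbonyl carbon, the six-membered non-aromatic ring with 1 hetero atom in place of the six-membered aromatic ring of carbon only gives an at least 26-fold higher number from compound 3 to compound 4 (1.41 log units; beyond the scatter).

This single pair cannot separate the loss of the aromatic ring from the gain of a ring nitrogen. A group carrying an amine or a carboxylic acid at this place lies outside the compounds shown, and its value in this assay stays open.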